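From compound 1 to compound 4: one group removed

The compounds below may be only part of what the source reports. "The series", "measured", "known", "first", "only" and "open" are said of these compounds alone.

Measured so far in a functional assay on Jurkat cells (Homo sapiens) for antiproliferative activity, read by MTT assay, with a stated time of 6 days; a lower number here means a stronger inhibitor, a higher number a weaker inhibitor:
- compound 1 `COc1ccc(/C=C/C(=O)OC[C@@H](OCc2ccccc2)[C@H]2OC(=O)C=C[C@H]2OCc2ccccc2)cc1`: 10300 nM
- compound 2 `COc1cccc(C(=O)OC[C@@H](OC(=O)c2cccc(OC)c2)[C@H]2OC(=O)C=C[C@H]2OC(=O)c2cccc(OC)c2)c1`: 21300 nM
- compound 3 `CC(=O)OC[C@@H](OC(C)=O)[C@H]1OC(=O)C=C[C@H]1OC(C)=O`: 24600 nM

Compound 1 has the lowest number of the three, which makes it the strongest inhibitor here. Its gaps to compound 2 and to compound 3 both lie beyond the usual scatter of repeated measurements, though neither gap is large.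

The next compound to be tested is compound 4 `O=C1C=C[C@@H](OCc2ccccc2)[C@@H]([C@@H](CO)OCc2ccccc2)O1`, which is made from the same pattern as compound 1 with one change: hydrogen in place of (2-(4-methoxyphenyl)ethenyl)carbonyl on an oxygen on a saturated carbon. In words, hydrogen stands in place of (2-(4-methoxyphenyl)ethenyl)carbonyl on an oxygen on a saturated carbon.

Within the data shown here, no measured pair isolates this change, so the data give no direct size for it. Among the measured compounds shown here, the only guide is the narrow spread of the set: compound 1 gives 10300 nM and compound 3 gives 24600 nM, even though their groups on the shared core differ. A small move toward a higher number, meaning a slightly weaker inhibitor, therefore seems most likely. The expected size is a 1.4-fold higher number from compound 1 to compound 4 (0.13 log units; within the scatter), which is not expected to exceed the scatter in this assay. Compound 4 is estimated at 14000 nM, with an expected range of 4500 nM to 40000 nM.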

Compound 4, half-maximal inhibitory concentration: 12300 nM
For compound 4 the middle estimate is 1.1-fold (0.06 log units) above the measured one; the range from low to high includes it.
By their numbers in this assay, from the lowest: compounds 1, 4, 2 and 3 (each within the scatter of the next, the first and the last beyond it).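

In this assay, replacing the (2-(4-methoxyphenyl)ethenyl)carbonyl group with hydrogen on this oxygen gives a 1.2-fold higher number from compound 1 to compound 4 (0.08 log units; within the scatter) and so leaves the two compounds indistinguishable. Among these compounds, this is the first measured pair to isolate a single change at this position, and it shows that all 12 heavy atoms of that group, including its aromatic ring, can be lost with no effect that this assay can detect, so the activity of compound 1 here does not depend on that group. Nothing measured here explains why the step is so small.

The compounds shown leave open whether a different group on this oxygen, such as an amine-bearing chain or a carboxylic acid, would shift the number beyond the scatter, or whether this position simply accepts whatever is placed there. They also leave open whether the other groups on the shared core can be removed just as freely, since each of those would need its own single-change pair to be read.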